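Cytotoxicity Limits in a Biaryl Amide Series: Compound 4

The source may hold more compounds than are shown below. What is called first, only, known or untested is meant among the compounds shown, and "the series" means these compounds.

Compound 1 `CC(C)COc1cccc(-c2ccc(C(=O)N(Cc3cccc(OCCCCCC(=O)O)c3)C(C)C)cc2)c1`, compound 2 `CCOc1cccc(-c2ccc(C(=O)N(Cc3cccc(OCCCCCC(=O)O)c3)C(C)C)cc2)c1` and compound 3 `CCOC(=O)CCCCCOc1cccc(CN(C(=O)c2ccc(-c3cccc(OCC(C)C)c3)cc2)C(C)C)c1` share one amide core. In an ADME assay on BJ cells (Homo sapiens) for cytotoxicity, read by CellTiter-Glo and resazurin assay, with a stated time of 72 h (a lower number here means that less compound is needed, a higher number that more compound is needed for the effect), compound 1 gives only a limit, > 26000 nM. Compound 2 likewise gives a limit in this assay, > 20800 nM. Compound 3 also gives a limit, > 26000 nM. Compound 3 thus sits at the limit of > 26000 nM in this assay, at which 2 of the 3 values shown sit, and the steps a step that the two limits leave unreadable from compound 1 to compound 2 and a step that the two limits leave unreadable from compound 1 to compound 3 reveal nothing about size. Compound 4 `CCOC(=O)CCCCCOc1cccc(CN(C(=O)c2ccc(-c3cccc(C(F)(F)F)c3)cc2)C(C)C)c1` differs from compound 3 by trifluoromethyl in place of isobutoxy on an aromatic carbon. Within the data shown here, no measured step touches this change, and every value in this assay so far is a limit, so no step beyond the scatter is expected. Compound 4 is therefore expected to show a step that the limit leaves unreadable from compound 3 to compound 4, an estimate of 30000 nM, between 10000 nM and 90000 nM.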

Compound 4, half-maximal effective concentration: < 1.3 nM
Compound 4: only a limit was reported; the forecaster's own chance of this, stated with the estimate: 80%; middle value at least 23000-fold (4.36 log units) away from the limit.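

In this assay, the aromatic carbon that carries isobutoxy in compound 3 proves to be a place where a single change matters: trifluoromethyl in place of isobutoxy gives an at least 20000-fold lower number from compound 3 to compound 4 (4.30 log units; beyond the scatter). Among these compounds, the earlier compounds offered only limits on one side, and their steps cannot be read, so this is the first step with a readable size. Compound 4 is the only compound shown with a limit on the low side: the limit of < 1.3 nM in this assay, at which 1 of the 4 values shown sits.

As far as these compounds go, how far compound 4 lies past its limit stays open. Also open, from the compounds shown here alone, is whether the step holds with a carboxylic acid in place of the ethyl ester on the chain, or with a nitrile on the same aromatic carbon.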